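Adding a Fluorine to the Benzyl Group: Cytotoxicity Outlook

The compounds below may be only part of what the source reports. "The series", "measured", "known", "first", "only" and "open" are said of these compounds alone.

Measured compounds in an ADME assay on HEL cells (Homo sapiens) for cytotoxicity, read by microscopy, with a stated time of 3 days; a higher number here means that more compound is tolerated, a lower number that less compound is tolerated:
Compound 1 `CCOC(=O)C1(Cc2ccccc2)CN(c2ccccc2)Cc2nnn(Cc3ccc(OC)cc3)c21` gives > 100000 nM, a limit of the assay.
Compound 2 `CCOC(=O)C1(Cc2ccccc2)CN(c2ccccc2)Cc2nnn(Cc3cccc(F)c3)c21` gives >= 100000 nM, a limit of the assay.
Compound 3 `CCOC(=O)C1(Cc2ccccc2)CN(c2ccccc2)Cc2nnn(CCCCCO)c21` gives > 100000 nM, a limit of the assay.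

Compound 2 stands at a limit, as do the other two values, so none of the three can be ranked. Compound 4 `CCOC(=O)C1(Cc2ccc(F)cc2)CN(c2ccccc2)Cc2nnn(Cc3cccc(F)c3)c21` differs from compound 2 by fluoro in place of hydrogen on an aromatic carbon. The measured steps a step that the two limits leave unreadable from compound 1 to compound 2, a step that the two limits leave unreadable from compound 1 to compound 3 and a step that the two limits leave unreadable from compound 2 to compound 3 all alter the group on the saturated chain carbon bound to an aromatic nitrogen, not the benzyl group, and their size is unreadable because every value sits at the limit of > 100000 nM in this assay, at which 2 of the 3 values shown sit, or (the limit of >= 100000 nM in this assay, at which 1 of the 3 values shown sits). Within the data shown here, no measured step bears on the change, so no shift beyond the scatter is expected: a number no higher from compound 2 to compound 4 (the limit leaves the size open). Compound 4 is expected to give 100000 nM, between 50000 nM and 200000 nM, most probably again only as a limit.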

Compound 4, minimum cytotoxic concentration: > 100000 nM
Compound 4 gave a limit, no number; the forecaster's own chance of this, stated with the estimate: 85%; the middle value sits exactly at the limit.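

Compound 2 and compound 4 both stand at a limit in this assay, so the step between them cannot be read. The compounds shown leave open whether fluoro in place of hydrogen changes how much compound is tolerated.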